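Swapping dipropylamino for (tert-butyl)amino

A few compounds are considered here, and "the series" means these few. Any claim that something is new, unique, unknown or untested is made for them only; others in the source may bear on it.

In a functional assay on SK-BR-3 cells (Homo sapiens) for antiproliferative activity (a higher number here means a weaker inhibitor, a lower number a stronger inhibitor), compound 3 (`CCCN(CCC)CCCOc1ccc2cc(NC(=O)c3ccc(O)c(CC=C(C)C)c3)c(=O)oc2c1C`) gives > 50000 nM as its result, and this is a limit of the assay, not a number. Compound 1 (`CC(C)=CCc1cc(C(=O)Nc2cc3ccc(OCCC4CCCCN4)c(C)c3oc2=O)ccc1O`) gives 640 nM and compound 2 (`CCCNCCCOc1ccc2cc(NC(=O)c3ccc(O)c(CC=C(C)C)c3)c(=O)oc2c1C`) gives 990 nM in the same test, and the two lie within the scatter, with a 1.5-fold higher number from compound 1 to compound 2 (0.19 log units; within the scatter) between them.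

Compound 4 (`CC(C)=CCc1cc(C(=O)Nc2cc3ccc(OCCCNC(C)(C)C)c(C)c3oc2=O)ccc1O`) carries (tert-butyl)amino in place of dipropylamino on a saturated chain carbon, three bonds along the chain from an oxygen on an aromatic ring.

Two large measured steps bear on this change. Putting propyl in place of hydrogen on an amine nitrogen gave an at least 50-fold higher number from compound 2 to compound 3 (1.70 log units; beyond the scatter) and the comparison with the piperidin-2-yl compound gave an at least 78-fold higher number from compound 1 to compound 3 (1.89 log units; beyond the scatter) as well. Compound 4 has a hydrogen on its amine nitrogen, as compound 1 and compound 2 do, so a large step to a lower number is expected in this assay here. The expected step is an at least 33-fold lower number from compound 3 to compound 4 (1.52 log units; beyond the scatter) on this estimate. Compound 4 is estimated at 1500 nM with an expected range from 400 nM to 8000 nM in this test.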

Compound 4, half-maximal inhibitory concentration: 660 nM
For compound 4 the middle estimate is 2.3-fold (0.36 log units) above the measured one; the measured number falls inside the stated range.
By their numbers in this assay, from the lowest: compounds 1, 4 and 2 (each within the scatter of the next). At a limit, above all of these: compound 3.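

Compound 3 stands at a limit of this assay, not at a number: the limit of > 50000 nM in this assay, at which 1 of the 4 values shown sits.

With (tert-butyl)amino in place of dipropylamino, the result returns to the range of the other compounds, with an at least 75-fold lower number from compound 3 to compound 4 (1.87 log units; beyond the scatter). The new compound also gives a third case with a hydrogen on the amine nitrogen, and it matches the earlier two, with a 1.5-fold lower number from compound 2 to compound 4 (0.18 log units; within the scatter) and a 1.0-fold higher number from compound 1 to compound 4 (0.01 log units; within the scatter), so tert-butyl on that nitrogen serves as well here as propyl or the piperidin-2-yl ring.

Among these four compounds, only the one without that hydrogen stands apart, but this single case cannot separate the loss of the hydrogen from the presence of two propyl groups. A dimethylamino group in the same place, which also lacks that hydrogen but carries much smaller groups, would help to tell the two apart.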